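This account rests on a few compounds, and the source may have more. Where it says the series, first, only, none or still open, it means among the compounds named here.

Working notes on the cytotoxicity series read in a functional assay on Huh-7 cells (Homo sapiens) for cytotoxicity, read by MTT assay, with a stated time of 3 days; a lower number here means that less compound is tolerated, a higher number that more compound is tolerated. Compound 1 `CC(=O)N(Cc1ccccc1)Cc1ncnc2c1ncn2[C@@H]1O[C@H](CO)[C@@H](O)[C@H]1O` gives only a limit of this assay, > 100000 nM. Compound 2 `OC[C@H]1O[C@@H](n2cnc3c(CSc4ccccn4)ncnc32)[C@H](O)[C@@H]1O` likewise gives only a limit of this assay, > 100000 nM. Compound 3 `OC[C@H]1O[C@@H](n2cnc3c(CS)ncnc32)C[C@@H]1O` gives a number in this assay, 41000 nM. Compound 2 therefore stands at the limit of > 100000 nM in this assay, at which 2 of the 3 values shown sit, with no number of its own. Compound 4 `O=C1CCCN1Cc1ncnc2c1ncn2[C@@H]1O[C@H](CO)[C@@H](O)[C@H]1O` is not yet measured; it differs from compound 2 by 2-oxopyrrolidin-1-yl in place of (pyridin-2-yl)sulfanyl on a saturated chain carbon bound to an aromatic carbon. Among the compounds with values here, no measured pair isolates this change, so no step for it is known. Compound 4 is expected to show no step beyond the scatter, a number no higher from compound 2 to compound 4 (the limit leaves the size open). Compound 4 is expected at 100000 nM, in the range 40000 nM to 250000 nM, most likely again as a limit.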

Compound 4, half-maximal cytotoxic concentration: 45000 nM
Estimate against measurement, compound 4: 2.2-fold (0.35 log units) above; low and high end bracket the measured number.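

In this assay, 2-oxopyrrolidin-1-yl in place of (pyridin-2-yl)sulfanyl on a saturated chain carbon bound to an aromatic carbon gives an at least 2.2-fold lower number from compound 2 to compound 4 (0.34 log units; beyond the scatter). Within the data shown here, this is the first change that can be read in one place, and it shows that the group at this position can move the number beyond the scatter. The true size of the step stays open because compound 2 has no number of its own: the limit of > 100000 nM in this assay, at which 2 of the 4 values shown sit.

The compounds shown leave open whether the step depends on the ring or on the carbonyl. They also do not show what a plain amine such as piperidin-1-yl or a carboxylic acid would give at this place.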